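The compounds below may be only part of what the source reports. "The series", "measured", "known", "first", "only" and "open" are said of these compounds alone.

Compound 1, `CC(C)(C)c1ccc(NC(=O)c2csc(Cc3c(Cl)cccc3Cl)n2)cc1`: 300 nM
Compound 2, `O=C(Nc1ccc(C(F)(F)F)cc1)c1csc(Cc2c(Cl)cccc2Cl)n1`: 88 nM
Compound 3, `O=C(Nc1ccc(C(F)(F)F)cc1)c1csc(-c2c(Cl)cccc2Cl)n1`: > 4000 nM

All three were measured in an assay on CHO cells, read by calcium flux; on this read-out lower numbers stand for stronger inhibition and higher numbers for weaker inhibition. For compound 3 the result is not a number but (the limit of > 4000 nM in this assay, at which 1 of the 3 values shown sits). Compound 4, `O=C(Nc1ccc(C(F)(F)F)cc1)c1csc(Oc2c(Cl)cccc2Cl)n1`, differs from compound 3 by 2,6-dichlorophenoxy in place of 2,6-dichlorophenyl on an aromatic carbon. Going by the values given here, one measured step bears on this: an at least 45-fold higher number from compound 2 to compound 3 (1.65 log units; beyond the scatter), where the 2,6-dichlorobenzyl, joined through a carbon, gave way to the directly attached 2,6-dichlorophenyl. Compound 4 again sets a linking atom, here oxygen, between the shared core and the dichlorinated ring, so a lower number is expected, though how far it returns toward the value of compound 2 is uncertain. Compound 4 is expected at 400 nM, between 60 nM and 4000 nM. The expected step is an at least 10-fold lower number from compound 3 to compound 4 (1.00 log units; beyond the scatter).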

Compound 4, half-maximal inhibitory concentration: 1280 nM
For compound 4 the middle estimate is 3.2-fold (0.51 log units) below the measured one, and the stated range covers the measured number.
By their numbers in this assay, from the lowest: compound 2; then compound 1; then compound 4. At a limit, above all of these: compound 3.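

In this assay, placing an oxygen link before the dichlorinated ring restores part of the activity lost with direct attachment: an at least 3.1-fold lower number from compound 3 to compound 4 (0.49 log units; beyond the scatter). Compound 3 gives only a limit of the assay, not a number: the limit of > 4000 nM in this assay, at which 1 of the 4 values shown sits. Oxygen does not match the carbon link, however, with a 15-fold higher number from compound 2 to compound 4 (1.16 log units; beyond the scatter), so at this position the identity of the linking atom matters, not only the presence of a link.

The compounds shown leave open how an amine link or a longer chain here would compare with the 2,6-dichlorobenzyl of compound 2. They also cannot tell why the oxygen link falls short of the carbon link.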